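The source may hold more compounds than are shown below. What is called first, only, known or untested is meant among the compounds shown, and "the series" means these compounds.

Two compounds share the same core and differ only in the group that hangs from it. Compound 1 `Nc1cc(N)c2nc(-c3ccccc3)c(Oc3ccc(Cl)c(Cl)c3)nc2c1` carries a 3,4-dichlorophenoxy group, and in a functional assay on Hs-578T cells (Homo sapiens) for inhibition, read by sulforhodamine B assay, with a stated time of 48 h (on this read-out higher numbers stand for weaker inhibition of growth and lower numbers for stronger inhibition of growth), compound 1 gives 10700 nM. Compound 2 `COc1cc(CNc2nc3cc(N)cc(N)c3nc2-c2ccccc2)cc(OC)c1OC` carries a different side group, and in this assay compound 2 gives 3020 nM. Of these two numbers, compound 1 holds the higher one, and the gap to compound 2 lies beyond the usual scatter of this kind of measurement.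

Compound 3 `Nc1cc(N)c2nc(-c3ccccc3)c(Oc3ccc(F)cc3)nc2c1` has not yet been measured. It differs from compound 1 in one place: 4-fluorophenyl in place of 3,4-dichlorophenyl on an oxygen on an aromatic ring. Among the compounds with values here, no pair of measured compounds shows what such a swap does, so the expectation rests on compound 1 alone. The step from compound 1 to compound 3 is expected to be small, a 1.3-fold higher number from compound 1 to compound 3 (0.12 log units; within the scatter), with no clear direction beyond the scatter. Compound 3 is therefore estimated at 14000 nM, within a range from 4500 nM to 45000 nM.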

Compound 3, concentration for 50% growth inhibition: 20000 nM
Beside the measured number, compound 3's estimate is 1.4-fold (0.15 log units) below it; the range from low to high includes it.
By their numbers in this assay, from the lowest: compound 2; then compounds 1 and 3 (each within the scatter of the next).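

Within the data shown here, replacing 3,4-dichlorophenyl with 4-fluorophenyl on the oxygen gives the first direct reading of a change at this position: in this assay the swap is a 1.9-fold higher number from compound 1 to compound 3 (0.27 log units; within the scatter) and so cannot be told apart from repeat-to-repeat variation. For this one pair, the aromatic ring can exchange two chlorine atoms for one fluorine atom with no change in growth inhibition that stands clear of the scatter. Nothing measured here offers an explanation for this result.

Going by these compounds, both groups seen on this oxygen are halogen-bearing phenyl rings, so it remains open what a plain phenyl ring, a simple methyl group, or a phenyl ring carrying a carboxylic acid or an amine would do. On these data alone, whether the same swap would also give so small a step on a different cell line also remains open.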